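A few compounds are considered here, and "the series" means these few. Any claim that something is new, unique, unknown or untested is made for them only; others in the source may bear on it.

Measured so far in an ADME assay on microsomes from liver (Homo sapiens) for metabolic stability, read by LC-MS, using NADPH, tested at 1 uM (a higher number here means faster removal of the compound, a lower number slower removal), for the series
compound 1 `CC(C)c1cnc(NC(=O)CCCOc2ccccc2)s1` gives 232 mL.min-1.g-1
compound 2 `Cc1cnc(NC(=O)CCCOc2cncc(Cl)c2)s1` gives 86 mL.min-1.g-1
compound 3 `Cc1cnc(NC(=O)NCCOc2ccc(Cl)c(C)c2)s1` gives 105 mL.min-1.g-1

Compound 1 stands highest of these three numbers. Its gaps to compound 2 and to compound 3 both lie beyond the scatter, while those two lie within the scatter of each other.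

Compound 4 `O=C(CCCOc1ccccc1)Nc1ncc(Cl)s1` has not yet been measured in this assay and is the next point of interest. Its difference from compound 1 is chloro in place of isopropyl on an aromatic carbon with chloro in place of isopropyl on an aromatic carbon, next to the ring sulfur.

Among the compounds with values here, no measured pair differs in one place only, so no direct step is available as a guide. Compound 2 at 86 mL.min-1.g-1 and compound 3 at 105 mL.min-1.g-1 both lack the isopropyl and sit lower than compound 1, but both also differ from it elsewhere, which makes them a loose guide only. On that basis, a downward step beyond the scatter is expected, towards slower removal. The expected step is a 2.2-fold lower number from compound 1 to compound 4 (0.34 log units; beyond the scatter) on this estimate. For compound 4 the estimated value is 105 mL.min-1.g-1 with an expected range from 50 mL.min-1.g-1 to 210 mL.min-1.g-1 in this measurement.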

Compound 4, intrinsic clearance in microsomes: 90 mL.min-1.g-1
The estimate for compound 4 lay 1.2-fold (0.07 log units) above the measured number; the measured number falls inside the stated range.
By their numbers in this assay, from the lowest: compounds 2, 4 and 3 (each within the scatter of the next); then compound 1.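

In this assay, the series now has its first step that isolates this position: a 2.6-fold lower number from compound 1 to compound 4 (0.41 log units; beyond the scatter), with chloro in place of isopropyl on an aromatic carbon, next to the ring sulfur, and the rest of the structure unchanged. The earlier lower numbers came only from compounds that also differed elsewhere, whereas this step shows that a change at this position alone moves the number beyond the scatter, towards slower removal. Nothing available accounts for the size or direction of the step, so it stands as an observation for this one pair.

Going by these compounds, whether the step reflects the arrival of chloro or the departure of isopropyl stays open, and a cyclopropyl, a trifluoromethyl or a nitrile at the same carbon on the core of compound 1 would help to separate the two. Within the data shown here, also open is whether the same exchange would give a step of similar size alongside the different side chains of compound 2 and compound 3, since the single step here rests on one side chain only.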